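This account rests on a few compounds, and the source may have more. Where it says the series, first, only, none or still open, it means among the compounds named here.

Compound 1 `COc1ccc(NC(=O)c2cc(Oc3ccc(/C=C/c4ccccn4)cc3)ccn2)cc1`: 20000 nM
Compound 2 `CNC(=O)c1cc(Oc2ccc(/C=C/c3ccncc3)cc2)ccn1`: 13200 nM
Compound 3 `O=C(Nc1ccccc1)c1cc(Oc2ccc(/C=C/c3ccncc3)cc2)ccn1`: 79700 nM

These three compounds were tested in a functional assay on A549 cells (Homo sapiens) for antiproliferative activity, read by CCK-8 assay, with a stated time of 48 h; a higher number here means a weaker inhibitor, a lower number a stronger inhibitor. Compound 3 stands at the highest number of the three, with compound 1 the nearer of the other two and compound 2 the furthest away. For the measured compounds named here, the only single-point step among them, a 6.0-fold higher number from compound 2 to compound 3 (0.78 log units; beyond the scatter), raised the number; no measured step isolates a methoxy group.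

Compound 4 `COc1ccc(NC(=O)c2cc(Oc3ccc(/C=C/c4ccncc4)cc3)ccn2)cc1` has not yet been measured. It differs from compound 3 by methoxy in place of hydrogen on an aromatic carbon. Going by the values given here, no measured step tests this exact change. Compound 1, which carries the same methoxy-bearing amide on a differently attached pyridine, gives 20000 nM, a lower number than compound 3 gives with 79700 nM, but the two differ in more than one place, so this is only a hint. The expectation for compound 4 is therefore a modest drop, a 2.7-fold lower number from compound 3 to compound 4 (0.42 log units; beyond the scatter), with wide uncertainty. The estimated value for compound 4 is 30000 nM, expected to fall between 10000 nM and 90000 nM.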

Compound 4, half-maximal inhibitory concentration: 25600 nM
Compound 4: the middle estimate sits 1.2-fold (0.07 log units) above what was measured; low and high end bracket the measured number.
By their numbers in this assay, from the lowest: compounds 2, 1 and 4 (each within the scatter of the next); then compound 3.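

Within this assay the change from phenyl to 4-methoxyphenyl on the amide nitrogen gives a 3.1-fold lower number from compound 3 to compound 4 (0.49 log units; beyond the scatter) and so shows that this place on the aromatic ring, para to a large group, responds to substitution. The other two steps, a 1.9-fold higher number from compound 2 to compound 4 (0.29 log units; within the scatter) and a 1.3-fold higher number from compound 1 to compound 4 (0.11 log units; within the scatter) are both within the scatter, so neither 4-methoxyphenyl in place of methyl nor pyridin-4-yl in place of pyridin-2-yl separates compound 4 from its partner. Nothing measured here gives a reason for the methoxy effect.

From the compounds shown here alone, whether this effect belongs to methoxy itself stays open, since a fluorine, a hydroxyl or a dimethylamino group at the same place might read differently. Also open, going by these compounds, is what a longer chain such as ethoxy would do there.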